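Replacing Chloro with Methoxy on a Pendant Phenyl Ring

The compounds below may be only part of what the source reports. "The series", "measured", "known", "first", "only" and "open" are said of these compounds alone.

The series shares one core: compound 1 `COc1cc(-c2nnc(SCc3cccc([N+](=O)[O-])c3)o2)ccc1O` carries a nitro group, compound 2 `COc1cc(-c2nnc(SCc3cccc(Cl)c3)o2)ccc1O` a chloro, and the unmeasured compound 3 `COc1cccc(CSc2nnc(-c3ccc(O)c(OC)c3)o2)c1` a methoxy. In an ADME assay on cells (Mus musculus, strain BALB/c) for cytotoxicity, read by MTT assay, with a stated time of 24 h (on this read-out lower numbers stand for higher toxicity in this test and higher numbers for lower toxicity in this test), compound 1 gives 392000 nM, and in this assay compound 2 gives 470000 nM. For the measured compounds named here, compound 2 therefore stands with the highest of the two numbers so far, but its nearest neighbour, compound 1, sits a 1.2-fold higher number from compound 1 to compound 2 (0.08 log units; within the scatter), so the two are indistinguishable. The move to compound 3 reads (methoxy in place of chloro on an aromatic carbon), a swap on the same aromatic carbon of the six-membered carbon-only ring, meta to a large group. Going by the values given here, the only measured step that bears on it is the earlier exchange at that position, which was a 1.2-fold higher number from compound 1 to compound 2 (0.08 log units; within the scatter); nothing in the data points to a change larger than the scatter for yet another small substituent there. Compound 3 is accordingly expected to show a 1.0-fold lower number from compound 2 to compound 3 (0.02 log units; within the scatter) in this assay. The estimate for compound 3 is 450000 nM, with a range from 200000 nM to 950000 nM.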

Compound 3, half-maximal cytotoxic concentration: 389000 nM
For compound 3 the middle estimate is 1.2-fold (0.06 log units) above the measured one; the range from low to high includes it.
By their numbers in this assay, from the lowest: compounds 3, 1 and 2 (each within the scatter of the next).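

In this assay, the exchange of chloro, one heavy atom with no hydrogen-bond acceptor, for methoxy, two heavy atoms with one hydrogen-bond acceptor, comes to a 1.2-fold lower number from compound 2 to compound 3 (0.08 log units; within the scatter) and so adds a heavier group without a step that can be told from the scatter. Set against the nitro group, the same methoxy group gives a 1.0-fold lower number from compound 1 to compound 3 (0.00 log units; within the scatter) on the same aromatic carbon, so this place, meta to a large group, now holds three groups whose numbers all lie within the scatter of one another, where the earlier pair offered only one exchange. No measurement given here bears on why these three groups read alike.

The compounds shown leave open whether this holds for a group of another kind at this place, such as an amine, a carboxylic acid or a longer chain, any of which could yet separate from the three groups seen here. They also leave open whether the exchange of 3-chlorophenyl for 3-methoxyphenyl would read the same on anything other than the shared core.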